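The source may hold more compounds than are shown below. What is called first, only, known or untested is meant among the compounds shown, and "the series" means these compounds.

Measured so far:
compound 1 `O=C(Nc1ccc(Cl)cc1)C(=O)N1CCC(c2ccnc3ccc(F)cc23)CC1` — in an assay on SK-OV-3 cells for inhibition of Indoleamine 2,3-dioxygenase 1 (Homo sapiens) (on this read-out higher numbers stand for weaker inhibition and lower numbers for stronger inhibition), compound 1 gives 15 nM
compound 2 `O=C(Nc1ccc(Cl)cn1)C(=O)N1CCC(c2ccnc3ccc(F)cc23)CC1` — compound 2 gives 70 nM

Among the measured compounds shown here, compound 1 holds the lowest of the two numbers; its only neighbour is compound 2, reached by a 4.7-fold higher number from compound 1 to compound 2 (0.67 log units; beyond the scatter). Compound 3 `O=C(Nc1ccc(Cl)cc1)C(=O)N1CC[C@@H](c2ccnc3ccc(F)cc23)[C@H](O)C1` differs from compound 1 by hydroxy in place of hydrogen on a saturated ring carbon. For the measured compounds named here, the single measured step concerns the aryl group on the amide nitrogen and does not bear on a change at the saturated ring, so nothing in the measured pair informs this move. The step of a 1.7-fold higher number from compound 1 to compound 3 (0.22 log units; within the scatter) is therefore expected to stay within the scatter, direction open. Compound 3 is estimated at 25 nM, range 8 nM to 80 nM.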

Compound 3, half-maximal inhibitory concentration: 50 nM
For compound 3 the middle estimate is 2.0-fold (0.30 log units) below the measured one; the measured number falls inside the stated range.
By their numbers in this assay, from the lowest: compound 1; then compounds 3 and 2 (each within the scatter of the next).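

In this assay, hydroxy on the saturated ring carbon next to the ring atom that bears a large group gives a 3.3-fold higher number from compound 1 to compound 3 (0.52 log units; beyond the scatter), a modest weakening of inhibition beyond the scatter. Among the compounds shown here, this is the first reading on the saturated ring, and it shows that this carbon is sensitive to substitution but that hydroxy there does not abolish inhibition. No available evidence bears on the reason for this step. From the compounds shown here alone, whether the drop is specific to hydroxy stays open, as methoxy, fluorine or an amine on the same carbon would show. Going by these compounds, the effect of the opposite stereochemistry at this carbon also stays open.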